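Swapping a bromophenyl for furan: cytotoxicity outlook

The source may hold more compounds than are shown below. What is called first, only, known or untested is meant among the compounds shown, and "the series" means these compounds.

Compound 1 `COc1nc2ccccc2cc1/C=C/c1noc(-c2ccccc2Br)n1` carries a 2-bromophenyl group on an aromatic carbon of the shared core. In an ADME assay on HepG2 cells (Homo sapiens) for cytotoxicity, read by sulforhodamine B assay, with a stated time of 48 h (a higher number here means that more compound is tolerated, a lower number that less compound is tolerated), compound 1 gives > 195000 nM, which is a limit of the assay rather than a measured number. Two close relatives stand beside it. Compound 2 `COc1nc2ccccc2cc1/C=C/c1noc(-c2cccc(Cl)c2)n1` carries a 3-chlorophenyl group in that place; in this assay compound 2 gives > 220000 nM, again a limit. Compound 3 `COc1nc2ccccc2cc1/C=C/c1noc(/C=C/c2ccccc2)n1` carries a 2-phenylethenyl group; in this assay compound 3 gives > 225000 nM, also a limit. The step that the two limits leave unreadable from compound 1 to compound 2 and the step that the two limits leave unreadable from compound 1 to compound 3 therefore cannot be sized, and neither can a step that the two limits leave unreadable from compound 2 to compound 3; the three values (the limit of > 195000 nM in this assay, at which 1 of the 3 values shown sits, (the limit of > 220000 nM in this assay, at which 1 of the 3 values shown sits), (the limit of > 225000 nM in this assay, at which 1 of the 3 values shown sits)) are limits and nothing more.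

Compound 4 `COc1nc2ccccc2cc1/C=C/c1noc(-c2ccco2)n1` is not yet measured. It differs from compound 1 in one place: furan-2-yl in place of 2-bromophenyl on an aromatic carbon. Because every measured neighbour of compound 1 sits at a limit (the limit of > 195000 nM in this assay, at which 1 of the 3 values shown sits, (the limit of > 220000 nM in this assay, at which 1 of the 3 values shown sits), (the limit of > 225000 nM in this assay, at which 1 of the 3 values shown sits)), there is no sign that exchanging the group on that carbon shifts tolerated concentration at all. The expected step is a step that the limit leaves unreadable from compound 1 to compound 4, no larger than the scatter. Compound 4 is expected to sit at 200000 nM in this assay, between 100000 nM and 400000 nM, most likely reported once more as a limit.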

Compound 4, half-maximal cytotoxic concentration: > 250000 nM
Compound 4 gave a limit, no number (the forecaster's own chance of this, stated with the estimate: 85%); at least 1.2-fold (0.09 log units) between middle value and limit.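

Compound 4 is reported in this assay only as a limit, as are compound 1, compound 2 and compound 3, and the steps from each of them to compound 4 cannot be read. The compounds shown leave open at what concentration any of the four becomes cytotoxic, and whether exchanging the group on that aromatic carbon changes the tolerated concentration at all.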